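The compounds below may be only part of what the source reports. "The series", "measured", "known", "first", "only" and "open" are said of these compounds alone.

For the measured compounds named here, compound 2 `O=C1Nc2ccc(C(=O)c3ccco3)cc2/C1=C/c1cc(Br)cc(Br)c1` gives 16% in an assay on HeLa cells for inhibition of Kinesin-like protein KIF15 (Homo sapiens), read by microscopy, with stated times of 2 s and 20 s, tested at 750 nM (on this read-out higher numbers stand for more inhibition at the one concentration tested (going by the name of the read-out) and lower numbers for less inhibition), the lowest of the two numbers so far; compound 1 `O=C1Nc2ccc(C(=O)c3ccco3)cc2/C1=C/c1cc(Cl)c(O)c(Br)c1` gives 62%, and the step of a number 46 percentage points lower from compound 1 to compound 2 (beyond the scatter) is large. Compound 3 `O=C1Nc2ccc(C(=O)c3ccco3)cc2/C1=C/c1ccnc(Cl)c1` carries 2-chloropyridin-4-yl in place of 3,5-dibromophenyl on a double-bonded chain carbon bound to a double-bonded ring carbon. Going by the values given here, no measured step bears directly on this change: the only step known exchanges one carbon-only aromatic ring for another and gives no guide to a ring with a hetero atom. With nothing in the numbers to anchor a direction, no step beyond the scatter is expected, and compound 3 is estimated at 20% (from 0% to 50%), a step of a number 4 percentage points higher from compound 2 to compound 3 (within the scatter).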

Compound 3, a percentage reported as inhibition, at one concentration (the size of the read-out at that concentration, not a potency): 15.8%
Estimate against measurement, compound 3: 4.2 percentage points above, and the stated range covers the measured number.
By their numbers in this assay, from the lowest: compounds 3 and 2 (each within the scatter of the next); then compound 1.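

In this assay, 2-chloropyridin-4-yl in place of 3,5-dibromophenyl on the double-bonded chain carbon gives a number 0.2 percentage points lower from compound 2 to compound 3 (within the scatter), so a ring with a hetero atom and a hydrogen-bond acceptor reads level with the carbon-only dibromo ring. With a number 46.2 percentage points lower from compound 1 to compound 3 (beyond the scatter), both groups now stand well apart from the group of compound 1. No measurement in hand explains either result. Open, as far as these compounds go, is whether the oxygen in the group of compound 1 accounts for its higher number, and how an amine or a carboxylic acid on this ring would read.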